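The source may report more compounds than this note shows. Statements on the series, on what has been measured and on what is new or still open speak of the compounds shown alone.

For the measured compounds named here, compound 2 `O=C(OC[C@H]1CN(c2ccc(-n3cc(-c4ccccn4)cn3)c(F)c2)C(=O)O1)c1ccccc1` stands highest of the two numbers so far in a physicochemical assay for lipophilicity, read by HPLC, measured as octanol-water partition; on this read-out higher numbers stand for higher lipophilicity and lower numbers for lower lipophilicity; compound 2 gives 4.21, while its nearest neighbour compound 1 `O=C1O[C@@H](CN2CCC(O)CC2)CN1c1ccc(-n2cc(-c3ccccn3)cn2)c(F)c1` gives 1.63. Going by the values given here, the one measured step, a number 2.58 log units higher from compound 1 to compound 2 (beyond the scatter), is large, and it is the only comparison available. Compound 3 `O=C1O[C@@H](CSc2cccs2)CN1c1ccc(-n2cc(-c3ccccn3)cn2)c(F)c1` differs from compound 2 by (thiophen-2-yl)sulfanyl in place of benzoyloxy on a saturated chain carbon bound to a saturated ring carbon. That step does not repeat the measured one: in the step from compound 1 to compound 2 a hydroxypiperidinyl group left and benzoyloxy entered, whereas here benzoyloxy itself leaves and a sulfur-linked aromatic group of six heavy atoms enters, so the measured step bears on it only loosely. With nothing closer to go on, the expected step of a number 0.19 log units higher from compound 2 to compound 3 (within the scatter) is small, within or just beyond the scatter, leaning upward. Compound 3 is therefore estimated at 4.4 in this assay, with a range from 3.8 to 5.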

Compound 3, partition coefficient: 4.29
Beside the measured number, compound 3's estimate is 0.11 log units above it, and the stated range covers the measured number.
By their numbers in this assay, from the lowest: compound 1; then compounds 2 and 3 (each within the scatter of the next).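

In this assay, the place on a saturated chain carbon bound to a saturated ring carbon now holds two different groups with no step beyond the scatter between them: (thiophen-2-yl)sulfanyl, with 6 heavy atoms, in place of benzoyloxy, with 9, gives a number 0.08 log units higher from compound 2 to compound 3 (within the scatter) and thus shows that the high reading of compound 2 does not depend on benzoyloxy alone. The large gap to 4-hydroxypiperidin-1-yl also recurs, with a number 2.66 log units higher from compound 1 to compound 3 (beyond the scatter) for a second, unrelated group, so compound 1 now stands apart from two compounds rather than one. Nothing available explains why these two groups read alike.

From the compounds shown here alone, it remains open where a dimethylamino group or a carboxylic acid at this place would fall between these readings. Going by these compounds, it is also open whether a phenylsulfanyl group would read like (thiophen-2-yl)sulfanyl.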